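Urea to amide: a guess from two measured compounds

A few compounds are considered here, and "the series" means these few. Any claim that something is new, unique, unknown or untested is made for them only; others in the source may bear on it.

The series shares one core, seen in compound 1 `COc1cc(-c2nn(-c3cccc(NC(=O)Nc4ccc(Cl)c(Cl)c4)c3)cc2-c2ccncc2)ccc1Cl` and compound 2 `COc1cc(-c2nn(-c3cccc(NC(=O)Nc4cccc(C(F)(F)F)c4)c3)cc2-c2ccncc2)ccc1Cl`. In a functional assay on A498 cells (Homo sapiens) for inhibition, read by sulforhodamine B assay, with a stated time of 48 h (on this read-out lower numbers stand for stronger inhibition of growth and higher numbers for weaker inhibition of growth), compound 1 gives 4590 nM, and in the same assay compound 2 gives 4040 nM. Among the compounds with values here, the single step between them, a 1.1-fold lower number from compound 1 to compound 2 (0.06 log units; within the scatter), leaves the two numbers indistinguishable. Within the data shown here, on the numbers so far, compound 2 therefore stands level with compound 1 and nothing more can be said of its rank.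

Compound 3 `COc1cc(-c2nn(-c3cccc(NC(=O)c4ccc(Cl)c(C(F)(F)F)c4)c3)cc2-c2ccncc2)ccc1Cl` departs from compound 2 by 4-chloro-3-(trifluoromethyl)phenyl in place of (3-(trifluoromethyl)phenyl)amino on a carbonyl carbon. Among the measured compounds shown here, only one measured step exists, and it exchanged aryl groups on the urea nitrogen rather than removing that nitrogen, so it bears on the new change only loosely: it showed that swapping one substituted phenyl for another at this end of the molecule moved the read-out by no more than the scatter. For the measured compounds named here, with no closer precedent, the expectation for compound 3 in this assay is a step of about a 1.0-fold lower number from compound 2 to compound 3 (0.00 log units; within the scatter), that is, none beyond the scatter. Compound 3 is thus estimated at 4000 nM, with a range from 1500 nM to 11000 nM.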

Compound 3, concentration for total growth inhibition: 22700 nM
Estimate against measurement, compound 3: 5.7-fold (0.75 log units) below; measured number above the stated range.
By their numbers in this assay, from the lowest: compounds 2 and 1 (each within the scatter of the next); then compound 3.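

Unlike the earlier step, which exchanged one aryl group for another on the urea nitrogen and stayed within the scatter, this change reaches the urea itself, and in this assay it gives a 5.6-fold higher number from compound 2 to compound 3 (0.75 log units; beyond the scatter) and, against the dichlorophenyl urea, a 4.9-fold higher number from compound 1 to compound 3 (0.69 log units; beyond the scatter) as well. Both steps lie beyond the scatter and point the same way, so at this position the urea compounds 1 and 2 inhibit growth more strongly than the amide compound 3, whichever of the two urea aryl groups is taken. The change removes the amino nitrogen and its hydrogen-bond donor and also brings in a chlorine on the aryl ring, and nothing available accounts for the loss.

The shown compounds do not separate those two parts of the change, so it remains open whether the 4-chloro-3-(trifluoromethyl)phenyl group would hold the level of compound 2 on an intact urea, or whether a plain 3-(trifluoromethyl)phenyl amide would fall as compound 3 does. Also open, as far as these compounds go, is how a methylene or an ether oxygen in place of the amino nitrogen would read in this assay on this core.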